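The compounds below may be only part of what the source reports. "The series", "measured", "known", "first", "only" and "open" are said of these compounds alone.

Compound 1 `CCOC(=O)C1=Cc2ccccc2OC1(OCc1cn(CC(=O)Nc2ccc(C)cc2)nn1)C(F)(F)F` was tested in a functional assay on DU-145 cells (Homo sapiens) for inhibition, read by MTT assay, with a stated time of 24 h; a lower number here means a stronger inhibitor, a higher number a weaker inhibitor. In this assay compound 1 gives > 150000 nM, which is a limit of the assay and not a number. Compound 2 `CCOC(=O)C1=Cc2ccccc2OC1(OCc1cc(-c2ccc(OC)cc2)no1)C(F)(F)F` was tested in the same way. In this assay compound 2 gives > 150000 nM, again a limit. Both results sit at the limit of > 150000 nM in this assay, at which 2 of the 2 values shown sit. Compound 3 `CCOC(=O)C1=Cc2ccccc2OC1(OCc1cn(-c2ccc(F)c(Cl)c2)nn1)C(F)(F)F` has not been measured; it differs from compound 1 by 3-chloro-4-fluorophenyl in place of ((4-methylphenyl)carbamoyl)methyl on an aromatic nitrogen. Going by the values given here, no step between measured compounds is available, so the expected step that the limit leaves unreadable from compound 1 to compound 3 is estimated to be none beyond the scatter. Compound 3 is expected to give 200000 nM, in the range 50000 nM to 800000 nM.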

Compound 3, half-maximal inhibitory concentration: 21500 nM
Estimate against measurement, compound 3: 9.3-fold (0.97 log units) above; the whole stated range lies above it.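

With 3-chloro-4-fluorophenyl in place of ((4-methylphenyl)carbamoyl)methyl on the aromatic nitrogen, this assay gives a readable value: compound 3 gives 21500 nM and the change makes an at least 6.9-fold lower number from compound 1 to compound 3 (0.84 log units; beyond the scatter) here. The result on this nitrogen can therefore move off the limit, which neither earlier compound showed. The full size of the step stays unknown because compound 1 gives only a limit: the limit of > 150000 nM in this assay, at which 2 of the 3 values shown sit.

As far as these compounds go, whether the chlorine, the fluorine or both are needed remains open. So does what an unsubstituted phenyl, a benzyl group or a short alkyl chain would give on this nitrogen.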